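Chloro on the Core: Compound 4 Before Its Measurement

The source may hold more compounds than are shown below. What is called first, only, known or untested is meant among the compounds shown, and "the series" means these compounds.

Compound 1, `COC(=O)[C@H](CC(C)C)NC(=O)c1cnc2ccccc2c1Cl`, in an ADME assay on CCRF-CEM cells (Homo sapiens) for cytotoxicity; on this read-out higher numbers stand for lower toxicity in this test and lower numbers for higher toxicity in this test: 49.1 uM.
Compound 2, `COC(=O)[C@H](CO)NC(=O)c1cnc2ccccc2c1Cl`: > 100 uM, a limit of the assay.
Compound 3, `CCOC(=O)[C@H](CO)NC(=O)c1cnc2ccccc2c1Cl`: > 100 uM, a limit of the assay.

Compound 2 stands at the limit of > 100 uM in this assay, at which 2 of the 3 values shown sit, so only a limit is known for it. Compound 4, `COC(=O)[C@H](CO)NC(=O)c1cnc2ccc(Cl)cc2c1Cl`, differs from compound 2 by chloro in place of hydrogen on an aromatic carbon. The measured steps, an at least 2.0-fold higher number from compound 1 to compound 2 (0.30 log units; that floor lies within the scatter) and a step that the two limits leave unreadable from compound 2 to compound 3, concern the side chain and the ester and not the aromatic ring, so neither bears directly on this change. Any number for compound 4 therefore rests on the limit of compound 2 alone, and no step beyond the scatter is expected. Compound 4 is estimated at 100 uM, between 40 uM and 250 uM, which is expected to mean a number no higher from compound 2 to compound 4 (the limit leaves the size open).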

Compound 4, half-maximal toxic concentration: > 100 uM
Compound 4 was reported as a limit (the forecaster's own chance of this, stated with the estimate: 60%); the middle value lies on the limit itself.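

Compound 4, like compound 2, is reported only as a limit of this assay, so no step can be read between them: the limit of > 100 uM in this assay, at which 3 of the 4 values shown sit.

Going by these compounds, whether chloro in place of hydrogen on an aromatic carbon alters the half-maximal toxic concentration at all remains open.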